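Carrying one methoxy change across to a second core

The compounds below may be only part of what the source reports. "The series", "measured", "known", "first", "only" and "open" are said of these compounds alone.

Measured compounds:
compound 1 `O=[N+]([O-])c1ccc(-c2scc3c2CCOC32CCN(Cc3ccccc3)CC2)cc1` 1.7 nM
compound 2 `COC1Cc2c(csc2-c2ccc([N+](=O)[O-])cc2)C2(CCN(Cc3ccccc3)CC2)O1` 1 nM
compound 3 `c1ccc(CN2CCC3(CC2)OCCc2cc(-c4ccccc4)sc23)cc1` 2.4 nM

In an assay on membranes from brain for displacement of a labelled ligand from Sigma non-opioid intracellular receptor 1 (Cavia porcellus), read by scintillation counting, with a stated time of 120 min (on this read-out lower numbers stand for stronger inhibition and higher numbers for weaker inhibition), compound 1 gives 1.7 nM. Compound 2 carries a single change relative to compound 1, namely (methoxy in place of hydrogen on a saturated ring carbon), and in this assay compound 2 gives 1 nM, so that the step is a 1.7-fold lower number from compound 1 to compound 2 (0.23 log units; within the scatter). Compound 3 rests on a different core; the difference between the two cores is not broken down here. In this assay compound 3 gives 2.4 nM, which stands close to the number for compound 1.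

Compound 4 `COC1Cc2cc(-c3ccccc3)sc2C2(CCN(Cc3ccccc3)CC2)O1` has not yet been measured. Relative to compound 3 it carries methoxy in place of hydrogen on a saturated ring carbon, the same change at the same place as the one from compound 1 to compound 2. Because a 1.7-fold lower number from compound 1 to compound 2 (0.23 log units; within the scatter) was small, the step is expected to be similarly modest: a 1.6-fold lower number from compound 3 to compound 4 (0.20 log units; within the scatter). On that basis compound 4 is estimated at 1.5 nM in this assay, with the expected range running from 0.6 nM to 4 nM.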

Compound 4, inhibition constant: 16 nM
Compound 4: the middle estimate sits 11-fold (1.03 log units) below what was measured, and the stated range ends below it.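

In this assay, methoxy in place of hydrogen on a saturated ring carbon gave a 6.7-fold higher number from compound 3 to compound 4 (0.82 log units; beyond the scatter), so the change did not behave on this core as it had on the core of compound 1. Set side by side, the two steps differ: the same change on two cores in this assay, a 1.7-fold lower number (0.23 log units; within the scatter) from compound 1 to compound 2 and a 6.7-fold higher number (0.82 log units; beyond the scatter) from compound 3 to compound 4, 11-fold (1.05 log units) apart, beyond the scatter of two such steps

This shows that, for these two pairs, the result of the change depends on the core it sits on, and that a step measured on one core was a poor guide to the step on the other. It does not show which difference between the cores matters, nor how the compounds come to differ, and two pairs set no rule for the wider series.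

The compounds shown leave open whether a hydroxyl or an ethoxy group on the same saturated ring carbon would also part the two cores in this way. They also leave open whether an amine at that place would follow the methoxy steps on either core.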